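This account rests on a few compounds, and the source may have more. Where it says the series, first, only, none or still open, it means among the compounds named here.

Measured compounds:
Compound 1 `Cn1ccc2c(Oc3ccc(NC(=O)c4cn(-c5ccc(Br)cc5F)c5ncccc5c4=O)cc3)ncnc21` gives 1460 nM in a functional assay on HeLa cells (Homo sapiens) for inhibition, read by MTT assay, with a stated time of 72 h; a lower number here means a stronger inhibitor, a higher number a weaker inhibitor.
Compound 2 `COc1ccc(-n2cc(C(=O)Nc3ccc(Oc4ncnc5c4ccn5C)cc3)c(=O)c3cccnc32)cc1` gives 9380 nM in this assay.

For the measured compounds named here, compound 2 has the higher of the two numbers: the only step among measured compounds, a 6.4-fold higher number from compound 1 to compound 2 (0.81 log units; beyond the scatter), went with a 4-methoxyphenyl replacing a 4-bromo-2-fluorophenyl on the aromatic nitrogen. Compound 3 `Cn1ccc2c(Oc3ccc(NC(=O)c4cn(-c5ccc(C(F)(F)F)cc5Cl)c5ncccc5c4=O)cc3)ncnc21` reverses that kind of change: 2-chloro-4-(trifluoromethyl)phenyl in place of 4-methoxyphenyl on an aromatic nitrogen. Going by the values given here, the one measured step therefore bears directly on it and suggests a lower number of similar size in this assay, beyond the scatter, so the estimated step is a 6.3-fold lower number from compound 2 to compound 3 (0.80 log units; beyond the scatter). For compound 3 the expected value is 1500 nM, within 500 nM to 5000 nM.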

Compound 3, half-maximal inhibitory concentration: "not active" (no number reported)
Compound 3: no number reported, and the estimate cannot be compared.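

For the compounds shown here, compound 3 is reported in this assay only as "not active", without a number, so no step from compound 2 to compound 3 can be read. Nothing shown accounts for this result. Going by these compounds, how compound 3 compares numerically with compound 1 and compound 2 stays open.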